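Solubility notes: from compound 1 to compound 4

The compounds below may be only part of what the source reports. "The series", "measured", "known", "first", "only" and "open" are said of these compounds alone.

Measured so far in a physicochemical assay for solubility; on this read-out higher numbers stand for higher solubility and lower numbers for lower solubility:
compound 1 `CNC(=O)c1cc(C(=O)NC2CC2)cn(CC2CCOCC2)c1=O`: >= 165 ug/mL, a limit of the assay
compound 2 `CCNC(=O)c1cc(C(=O)NC)c(=O)n(Cc2ccccc2)c1`: >= 144 ug/mL, a limit of the assay
compound 3 `CNC(=O)c1cc(C(=O)NC2CC2)cn([C@H](C)c2ccccc2)c1=O`: >= 168 ug/mL, a limit of the assay

Compound 1 stands at the limit of >= 165 ug/mL in this assay, at which 1 of the 3 values shown sits. The two other values are limits as well, the limit of >= 144 ug/mL in this assay, at which 1 of the 3 values shown sits, and (the limit of >= 168 ug/mL in this assay, at which 1 of the 3 values shown sits), so none of the three can be placed above another. For the measured compounds named here, the one step between measured compounds, a step that the two limits leave unreadable from compound 1 to compound 3, is of unreadable size. Compound 4 `CNC(=O)c1cc(C(=O)NC2CC2)cn(Cc2cccc3cn[nH]c23)c1=O` differs from compound 1 by 1H-indazol-7-yl in place of oxan-4-yl on a saturated chain carbon bound to an aromatic nitrogen. Going by the values given here, no measured step bears readably on this change, so no direction beyond the scatter is expected, and compound 4 is expected to sit near the same limit region as compound 1. The estimate for compound 4 in this assay is 150 ug/mL, range 60 ug/mL to 320 ug/mL. The expected step is an at least 1.1-fold lower number from compound 1 to compound 4 (0.04 log units; that floor lies within the scatter).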

Compound 4, solubility: >= 181 ug/mL
Compound 4: only a limit was reported (the forecaster's own chance of this, stated with the estimate: 65%); middle value at least 1.2-fold (0.08 log units) away from the limit.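

In this assay compound 4 gives >= 181 ug/mL, a limit of the assay. For the compounds shown here, compound 1 gives >= 165 ug/mL, also a limit, so no step from compound 1 to compound 4 can be read. The compounds shown leave open where any of the true values lie.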